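This account rests on a few compounds, and the source may have more. Where it says the series, first, only, none or still open, it means among the compounds named here.

Measured compounds:
compound 1 `COC(=O)c1scc(-c2ccc(NC(=O)c3ccc(OC)nc3)cc2)c1OC`, 15300 nM
compound 2 `COC(=O)c1scc(-c2ccc(NC(=O)c3ccc(C#N)nc3)cc2)c1OC`, 28500 nM
compound 3 `COC(=O)c1scc(-c2ccc(NC(=O)c3ccccn3)cc2)c1OC`, 8250 nM

In a functional assay on MDA-MB-231 cells (Homo sapiens) for antiproliferative activity, read by MTT assay, with a stated time of 24 h (a lower number here means a stronger inhibitor, a higher number a weaker inhibitor), compound 3 returns the lowest of the three numbers. Its gap to compound 1 is small, a 1.9-fold lower number from compound 1 to compound 3 (0.27 log units; within the scatter), and only against compound 2 does the gap pass beyond the scatter, a 3.5-fold lower number from compound 2 to compound 3 (0.54 log units; beyond the scatter). Compound 1 and compound 2 themselves sit close together, a 1.9-fold higher number from compound 1 to compound 2 (0.27 log units; within the scatter).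

The next compound, compound 4 `COC(=O)c1scc(-c2ccc(NC(=O)c3cccc(I)c3)cc2)c1OC`, differs from compound 3 in one place: 3-iodophenyl in place of pyridin-2-yl on a carbonyl carbon.

Both earlier steps that touch this same position, the swap from compound 1 to compound 3 and the swap from compound 2 to compound 3, exchanged one six-membered aromatic ring for another and moved the number by no more than a modest amount. Among the compounds with values here, neither of them, however, replaced a ring holding a nitrogen with a ring of carbon only, nor introduced an iodine, so the present change has no direct precedent among the measured compounds. Given how little the earlier swaps on the carbonyl carbon shifted the readout, compound 4 is expected to stay near compound 3, with a step of a 1.1-fold higher number from compound 3 to compound 4 (0.04 log units; within the scatter) that need not exceed the scatter in either direction. The estimate for compound 4 in this assay is therefore 9000 nM, with a range from 3000 nM to 27000 nM.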

Compound 4, half-maximal inhibitory concentration: 8240 nM
For compound 4 the middle estimate is 1.1-fold (0.04 log units) above the measured one, within the range that was stated.
By their numbers in this assay, from the lowest: compounds 4, 3, 1 and 2 (each within the scatter of the next, the first and the last beyond it).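

In this assay, replacing a ring that holds a nitrogen with a ring of carbon only that carries an iodine gives a step within the scatter (a 1.0-fold lower number from compound 3 to compound 4 (0.00 log units; within the scatter)), so in this one pair, losing the ring nitrogen and its hydrogen-bond acceptor goes with no measurable change. The group 3-iodophenyl also matches the pattern seen with pyridin-2-yl against the other two groups on this carbonyl carbon: its gap to 6-cyanopyridin-3-yl lies beyond the scatter (a 3.5-fold lower number from compound 2 to compound 4 (0.54 log units; beyond the scatter)), while its gap to 6-methoxypyridin-3-yl stays within it (a 1.9-fold lower number from compound 1 to compound 4 (0.27 log units; within the scatter)). The data shown offer no measured evidence that would explain these results.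

Every group shown at this position is a six-membered aromatic ring, so it remains open whether a saturated ring such as piperidine, or a chain ending in an amine or a carboxylic acid, would keep the number at the level of compound 3 and compound 4. The compounds also leave open what the iodine contributes, since plain phenyl does not appear among them to set against 3-iodophenyl.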